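Methyl on the phenoxy ring: what happens to cytotoxicity

This account rests on a few compounds, and the source may have more. Where it says the series, first, only, none or still open, it means among the compounds named here.

Compound 1 `COc1ncnc(Nc2ccc(Cl)c(OCC=C(C)C)c2)n1`: 18000 nM in an ADME assay on MT2 cells (Homo sapiens) for cytotoxicity; on this read-out higher numbers stand for lower toxicity in this test and lower numbers for higher toxicity in this test
Compound 2 `COc1nc(C)nc(Nc2ccc(Cl)c(OCC=C(C)C)c2)n1`: 12000 nM
Compound 3 `COc1ccnc(Nc2ccc(Cl)c(Oc3ccccc3)c2)n1`: 38000 nM

Compound 3 gives the highest number of the three in this assay. How its core differs from that of compound 1 is not broken down here. Compound 4 `COc1ccnc(Nc2ccc(Cl)c(Oc3ccccc3C)c2)n1` is not yet measured; it arises from compound 3 by methyl in place of hydrogen on an aromatic carbon. The same kind of change, (methyl in place of hydrogen on an aromatic carbon), is seen from compound 1 to compound 2, where it made a 1.5-fold lower number from compound 1 to compound 2 (0.18 log units; within the scatter). The surroundings differ, though: in compound 2 the methyl sits on a six-membered aromatic ring with 3 nitrogen, between two ring nitrogen atoms, meta to a large group and meta to a methoxy group, while in compound 4 it sits on a six-membered aromatic ring of carbon only, ortho to a large group. Because compound 2 showed only a 1.5-fold lower number from compound 1 to compound 2 (0.18 log units; within the scatter), a step of similar size, a 1.3-fold lower number from compound 3 to compound 4 (0.10 log units; within the scatter), is expected here. Compound 4 is therefore estimated at 30000 nM, between 13000 nM and 70000 nM.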

Compound 4, half-maximal cytotoxic concentration: 13000 nM
For compound 4 the middle estimate is 2.3-fold (0.36 log units) above the measured one; the range from low to high includes it.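

The change from phenoxy to 2-methylphenoxy gives a 2.9-fold lower number from compound 3 to compound 4 (0.47 log units; beyond the scatter) in this assay. Set beside the earlier step on the core of compound 1, the size of the change carries over between the two cores with no difference beyond the scatter: the same change on two cores in this assay, a 1.5-fold lower number (0.18 log units; within the scatter) from compound 1 to compound 2 and a 2.9-fold lower number (0.47 log units; beyond the scatter) from compound 3 to compound 4, 1.9-fold (0.29 log units) apart, within the scatter of two such steps This rests on two pairs only, with the methyl in different surroundings, and it does not show that a step of this size would hold on a further core or why the number falls on the core of compound 3.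

The compounds shown leave open whether an ethyl group or a methoxy group in place of this methyl would give a step of like size. They also leave open how an amine or a carboxylic acid at that place would read in this assay.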